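Methoxy added to the phenyl of compound 3

The source may report more compounds than this note shows. Statements on the series, on what has been measured and on what is new or still open speak of the compounds shown alone.

Of the compounds shown here, three of the shared core have been measured in an assay on isolated protein for inhibition of RAC-beta serine/threonine-protein kinase (Homo sapiens), read by mobility shift assay, tested at 30 uM; on this read-out lower numbers stand for less inhibition and higher numbers for more inhibition at the one concentration tested (going by the name of the read-out). Compound 1 `COc1ccc(-c2cc3[nH]nc(N)c3c(=O)[nH]2)cc1` gives 11%; compound 2 `Cc1cc2c(c(N)nn2C)c(=O)[nH]1` gives 4%; compound 3 `Cn1nc(N)c2c(=O)[nH]c(-c3ccccc3)cc21` gives 4%. Compound 3 is level with compound 2, together the lowest of the three numbers, and compound 1 stands only a few points higher, within the scatter. For the measured compounds named here, the one measured step, no change at the digits printed from compound 2 to compound 3 (within the scatter), shows that phenyl in place of methyl left the read-out unchanged.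

Compound 4 `COc1ccc(-c2cc3c(c(N)nn3C)c(=O)[nH]2)cc1` differs from compound 3 by methoxy in place of hydrogen on an aromatic carbon. Going by the values given here, no measured step covers methoxy in place of hydrogen; compound 1 carries that methoxy on a different core and its value and that of compound 3 lie within the scatter of one another. No step beyond the scatter is therefore expected in this assay: the expected step is a number 2 percentage points higher from compound 3 to compound 4 (within the scatter). Compound 4 is estimated at 6%, with a range from 0% to 16%.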

Compound 4, a percentage reported as inhibition, at one concentration (the size of the read-out at that concentration, not a potency): -8%
Compound 4: middle estimate off by 14 percentage points, on the high side; measured number outside the range, below it.
By their numbers in this assay, from the lowest: compound 4; then compounds 2, 3 and 1 (each within the scatter of the next).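

In this assay, for the compounds shown here, the aromatic position para to a large group responds to substitution: methoxy in place of hydrogen gives a number 12 percentage points lower from compound 3 to compound 4 (beyond the scatter), the first step beyond the scatter. With that methoxy present, the aromatic nitrogen also matters, as methyl in place of hydrogen gives a number 19 percentage points lower from compound 1 to compound 4 (beyond the scatter). Nothing measured gives a cause for either step. Open, as far as these compounds go, is whether a hydroxyl or an amine at the methoxy position gives a similar step. Also open, from the compounds shown here alone, is how a longer chain on the aromatic nitrogen reads in this assay.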